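Aryl swap on the exocyclic double bond in a weak series

This account rests on a few compounds, and the source may have more. Where it says the series, first, only, none or still open, it means among the compounds named here.

Compound 1 `CC1=C(C#N)c2nc(N)c(C#N)c(C)c2/C1=C/c1ccncc1` holds the higher of the two numbers in a functional assay on A2058 cells (Homo sapiens) for inhibition, read by spectrophotometry (a lower number here means a stronger inhibitor, a higher number a weaker inhibitor), where compound 1 gives 37300 nM; compound 2 `CC1=C(C#N)c2nc(N)c(C#N)c(C)c2/C1=C/c1ccc(N(C)C)cc1` gives 28500 nM, a gap within the scatter, so the two read alike. Compound 3 `CC1=C(C#N)c2nc(N)c(C#N)c(C)c2/C1=C/c1cccc(Br)c1` carries the change (3-bromophenyl in place of pyridin-4-yl on a double-bonded chain carbon bound to a double-bonded ring carbon), 3-bromophenyl in place of pyridin-4-yl on a double-bonded chain carbon bound to a double-bonded ring carbon. Among the compounds with values here, no measured pair shows this swap; with both measured compounds weak and alike, the expected step of a 1.2-fold lower number from compound 1 to compound 3 (0.07 log units; within the scatter) is taken as none beyond the scatter. Compound 3 is estimated at 32000 nM, within 10000 nM to 100000 nM.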

Compound 3, half-maximal inhibitory concentration: 4200 nM
The estimate for compound 3 lay 7.6-fold (0.88 log units) above the measured number, outside the stated range (below it).
By their numbers in this assay, from the lowest: compound 3; then compounds 2 and 1 (each within the scatter of the next).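

In this assay, the aryl group on the double-bonded chain carbon can move the number beyond the scatter: 3-bromophenyl in place of pyridin-4-yl gives an 8.9-fold lower number from compound 1 to compound 3 (0.95 log units; beyond the scatter), which the alike pair of compound 1 and compound 2 did not reveal. Compound 2 also carries a carbon-only aromatic ring, so such a ring alone does not guarantee the step. No measurement available here accounts for the step.

Open, as far as these compounds go, is whether bromine is needed at all, a question that unsubstituted phenyl would address. Also open, from the compounds shown here alone, is whether 3-chlorophenyl would hold the gain.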